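Sulfonyl Aryl Exchanges Before a Nitrile Analogue

The source may report more compounds than this note shows. Statements on the series, on what has been measured and on what is new or still open speak of the compounds shown alone.

Of the compounds shown here, three on one shared core have been tested in an assay on isolated protein for displacement of a labelled ligand from metabotropic glutamate receptor 5 (Homo sapiens), with a stated time of 60 min, tested at 1 uM; a lower number here means less inhibition, a higher number more inhibition at the concentration tested (going by the name of the read-out). Compound 1 `COc1ccc(S(=O)(=O)c2cnc3ccc(F)cc3c2N2CCC(C)CC2)cc1` gives 85%. Compound 2 `Cc1ccc(S(=O)(=O)c2cnc3ccc(F)cc3c2N2CCC(C)CC2)cc1F` gives 86%. Compound 3 `CC1CCN(c2c(S(=O)(=O)c3cccc(Cl)c3)cnc3ccc(F)cc23)CC1` gives 92%, the highest of the three numbers, though its gaps to compound 2 and to compound 1 both lie within the scatter, so no order among the three is claimed.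

The measured steps all exchange the aryl group on the sulfonyl sulfur. There is a number 1 percentage points higher from compound 1 to compound 2 (within the scatter) for 3-fluoro-4-methylphenyl in place of 4-methoxyphenyl, a number 7 percentage points higher from compound 1 to compound 3 (within the scatter) for 3-chlorophenyl in place of 4-methoxyphenyl, and a number 6 percentage points higher from compound 2 to compound 3 (within the scatter) for 3-chlorophenyl in place of 3-fluoro-4-methylphenyl. None of them moves beyond the scatter.

Compound 4 `CC1CCN(c2c(S(=O)(=O)c3ccc(C#N)cc3)cnc3ccc(F)cc23)CC1` differs from compound 3 in the same place: 4-cyanophenyl in place of 3-chlorophenyl on a sulfonyl sulfur. Since every measured exchange of the aryl on the sulfonyl sulfur stayed within the scatter, the expectation for this assay is again no step beyond the scatter, with compound 3 as the reference. Compound 4 is therefore expected to give 85%, within a range from 70% to 97%. The estimated step is a number 7 percentage points lower from compound 3 to compound 4 (within the scatter), expected to fall inside the usual scatter.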

Compound 4, a percentage reported as inhibition, at one concentration (the size of the read-out at that concentration, not a potency): 75%
Estimate against measurement, compound 4: 10 percentage points above; the range from low to high includes it.
By their numbers in this assay, from the lowest: compounds 4, 1, 2 and 3 (each within the scatter of the next, the first and the last beyond it).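

In this assay the aryl group on the sulfonyl sulfur proves able to move the read-out beyond the scatter, which no earlier exchange at this position had done: there is a number 17 percentage points lower from compound 3 to compound 4 (beyond the scatter) for 4-cyanophenyl in place of 3-chlorophenyl, and a number 11 percentage points lower from compound 2 to compound 4 (beyond the scatter) for 4-cyanophenyl in place of 3-fluoro-4-methylphenyl, both modest in size. Compound 1 goes against any reading that the nitrile sets compound 4 apart from every other aryl group shown, as the exchange of methoxy for cyano on an aromatic carbon gives a number 10 percentage points lower from compound 1 to compound 4 (within the scatter) and so does not leave the scatter. Nothing in the data shown bears on why this exchange produces the steps it does.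

As far as these compounds go, whether these steps follow the nitrile itself remains open, as the other aryl groups carry only methoxy, methyl, fluoro or chloro substituents. From the compounds shown here alone, how a carboxylic acid or a primary amide in place of the cyano group would read at this position is also open, as is whether these single-concentration percentages would hold up as differences in potency.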